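The source may hold more compounds than are shown below. What is called first, only, known or untested is meant among the compounds shown, and "the series" means these compounds.

In a functional assay (Homo sapiens) for inhibition (on this read-out higher numbers stand for weaker inhibition and lower numbers for stronger inhibition), compound 1 (`O=C(/C=C/c1ccc(F)cc1)c1ccc(C2CCCCC2)cc1`) gives 74000 nM, compound 2 (`COc1cc(/C=C/C(=O)c2ccccc2F)cc(OC)c1`) gives 6000 nM and compound 3 (`COc1cc(/C=C/C(=O)c2cccc(N(C)C)c2)cc(OC)c1`) gives 5000 nM. Compound 3 lies within the scatter of compound 2, while its gap to compound 1 lies beyond the scatter, with compound 1 at the much higher number.

The compound still to be measured is compound 4 (`COc1cc(/C=C/C(=O)c2cccc(F)c2)cc(OC)c1`). It has fluoro in place of dimethylamino on an aromatic carbon, meta to a large group: fluoro in place of dimethylamino on an aromatic carbon.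

Going by the values given here, no measured pair isolates this change, so the evidence for it is indirect. Compound 2 also carries fluoro and gives 6000 nM, which offers no sign that a fluoro compound must depart far from compound 3. No change beyond the scatter, in either direction, is therefore expected in this assay. The expected result is a 1.2-fold higher number from compound 3 to compound 4 (0.08 log units; within the scatter), an estimate that leans slightly toward a higher number. For compound 4 the estimated value is 6000 nM, with an expected range of 2500 nM to 14000 nM.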

Compound 4, half-maximal inhibitory concentration: 9200 nM
For compound 4 the middle estimate is 1.5-fold (0.19 log units) below the measured one, and the stated range covers the measured number.
By their numbers in this assay, from the lowest: compounds 3, 2 and 4 (each within the scatter of the next); then compound 1.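

In this assay, fluoro in place of dimethylamino on an aromatic carbon gives a 1.8-fold higher number from compound 3 to compound 4 (0.26 log units; within the scatter), so losing the dimethylamino group and its hydrogen-bond acceptor produces no change that can be told from the scatter. The 3-fluorophenyl in place of 2-fluorophenyl on a carbonyl carbon gives a 1.5-fold higher number from compound 2 to compound 4 (0.19 log units; within the scatter), so moving the fluoro also produces no readable change. Nothing available here offers an explanation for either result.

How a carboxylic acid or a primary amine would read at this place remains open, as the compounds shown carry only dimethylamino and fluoro there. Compound 1 stays unconnected to the others by any single change, so no one group can be tied to its higher number.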